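A few compounds are considered here, and "the series" means these few. Any claim that something is new, unique, unknown or untested is made for them only; others in the source may bear on it.

In an ADME assay on a cell-free system (plasma, Homo sapiens) for protein binding, compound 1 `CNc1nccc(N2CC[C@H](NC(=O)Nc3cccc(C#N)c3)C2)n1` gives 94.4% and stands level with its nearest neighbour. Compound 3 `CNc1nccc(N2CC[C@H](NC(=O)Nc3ccc(OC(F)F)cc3)C2)n1` gives 93.8% within the scatter of that value. Compound 2 `O=C(Nc1ccc(Cl)c(C(F)(F)F)c1)N[C@H]1CCN(c2ccnc(NC3CC3)n2)C1` reads > 99.9% as a limit of the assay and not a number. Compound 4 `CNc1nccc(N2CC[C@H](NC(=O)Nc3cccc(OC)c3)C2)n1` carries methoxy in place of cyano on an aromatic carbon and otherwise matches compound 1. Going by the values given here, no measured pair isolates this change, so the expectation in this assay is no step beyond the scatter, resting on compound 3 at 93.8% as the closest numeric reference. The expected size of the step (a 1.3-fold higher unbound fraction from compound 1 to compound 4 (0.10 log units; within the scatter)) stays within the scatter. For compound 4 the estimated value is 93% with an expected range from 88% to 96.5% in this series.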

Compound 4, plasma protein binding: 96.7%
The estimate for compound 4 lay 2.1-fold (0.33 log units) (unbound fraction) above the measured number; measured number above the stated range.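

In this assay, going by these compounds alone, the first matched change, 3-cyanophenyl to 3-methoxyphenyl, gives a 1.7-fold lower unbound fraction from compound 1 to compound 4 (0.23 log units; within the scatter). At this place, on an aromatic carbon meta to a large group, methoxy in place of cyano therefore leaves the read-out level with compound 1 for this single pair. Compound 2 carries the only limit, which is not a number: the limit of > 99.9% in this assay, at which 1 of the 4 values shown sits.

On these data alone, whether an amine or a carboxylic acid at this place would give a step beyond the scatter stays open. A single pair also leaves open whether this step holds on other members of the series.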